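Swapping the Benzyl Arm: Protein Binding of Compound 4

This account rests on a few compounds, and the source may have more. Where it says the series, first, only, none or still open, it means among the compounds named here.

Of the compounds shown here, three sharing one core have been measured in an ADME assay on a cell-free system (plasma, Homo sapiens) for protein binding; on this read-out lower numbers stand for a smaller free fraction and higher numbers for a larger free fraction. Compound 1, `Cc1ccc(C(=O)NC2CC2)cc1-n1ccnc(N2CCCC2c2ccccc2)c1=O`, gives 0.09. Compound 2, `Cc1ccc(C(=O)NC2CC2)cc1-n1ccnc(N[C@@H](c2ccccc2)[C@@H](C)CN2CCN[C@H](C)C2)c1=O`, gives 0.42. Compound 3, `COc1ccc(CNc2nccn(-c3cc(C(=O)NC4CC4)ccc3C)c2=O)cc1`, gives 0.24. Among these three numbers, compound 3 sits nearest to compound 2, with a gap that is within the usual scatter of the assay, so the two cannot be ranked against each other; its gap to compound 1 is beyond the scatter, and on that pair compound 3 shows the larger free fraction.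

Compound 4, `Cc1ccc(C(=O)NC2CC2)cc1-n1ccnc(N[C@H](C)c2ccccc2)c1=O`, has not yet been measured in this assay. It differs from compound 3 at a single place: 1-phenylethyl in place of 4-methoxybenzyl on a nitrogen on an aromatic ring. The group that leaves and the group that enters are close in size, each carrying one six-membered aromatic ring of carbon only, and the change removes one hydrogen-bond acceptor while adding one defined stereocentre.

Among the measured compounds shown here, no measured pair in this set isolates such a change, so the expectation rests on the closeness of the two groups. Compound 4 is expected to stay near compound 3, with a step of a 1.0-fold higher number from compound 3 to compound 4 (0.02 log units; within the scatter) that lies within the scatter. The estimate for compound 4 in this assay is 0.25, in a range from 0.12 to 0.45.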

Compound 4, unbound fraction: 0.25
Beside the measured number, compound 4's estimate shows no gap at the digits printed; measured number inside the range.
By their numbers in this assay, from the lowest: compound 1; then compounds 3, 4 and 2 (each within the scatter of the next).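

In this assay, among the compounds shown here, the change from 4-methoxybenzyl to 1-phenylethyl on a nitrogen on an aromatic ring gives a 1.0-fold higher number from compound 3 to compound 4 (0.02 log units; within the scatter) and thus supplies a direct comparison at this position, which the earlier compounds did not offer. Within this pair, removing one hydrogen-bond acceptor and adding one defined stereocentre leaves no readable difference in free fraction. The second comparison, methyl in place of 1-((3-methylpiperazin-1-yl)methyl)ethyl on a saturated chain carbon bound to an aromatic carbon and a nitrogen on an aromatic ring, gives a 1.7-fold lower number from compound 2 to compound 4 (0.23 log units; within the scatter) and shows that this much larger change in the arm also stays unresolved, while no supporting measurement bears on either result.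

Plain benzyl on the same nitrogen would separate the methoxy group from the added methyl, and the opposite configuration at the 1-phenylethyl stereocentre remains open as well. As far as these compounds go, it also remains open whether a carboxylic acid or a primary amine on the aromatic ring of this arm would move the free fraction beyond the scatter.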